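A few compounds are considered here, and "the series" means these few. Any claim that something is new, unique, unknown or untested is made for them only; others in the source may bear on it.

Working notes on the series. Within the data shown here, compound 1 `CCCCc1ccc(-c2cc(=O)c3c(o2)C(CC)(CC)C(=O)C(CC)=C3O)cc1` is the only member with a number in a functional assay on KB cells (Homo sapiens) for antiproliferative activity, read by sulforhodamine B assay, with a stated time of 3 days; a higher number here means that more compound is needed for the effect, a lower number that less compound is needed: compound 1 gives 111 uM. Compound 2 `CCCOc1ccc(-c2cc(=O)c3c(o2)C(CC)(CC)C(=O)C(CC)=C3O)cc1` reaches only a limit in this assay, where compound 2 gives > 50.5 uM, the limit recorded as the limit of > 50.5 uM in this assay, at which 1 of the 3 values shown sits. Compound 3 `CCC1=C(O)c2c(oc(-c3ccc(CBr)cc3)cc2=O)C(CC)(CC)C1=O` likewise stops at a limit in this assay, where compound 3 gives > 46.5 uM, the limit recorded as the limit of > 46.5 uM in this assay, at which 1 of the 3 values shown sits. Compound 3 therefore stands among the two of three values that are limits rather than numbers, and the step that the limit leaves unreadable from compound 1 to compound 3 cannot be read for size. The same holds for a step that the limit leaves unreadable from compound 1 to compound 2 and for a step that the two limits leave unreadable from compound 2 to compound 3, the last sitting between two limits.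

Compound 4 `CCC1=C(O)c2c(oc(-c3cc(C)c(C)cc3C)cc2=O)C(CC)(CC)C1=O` differs from compound 3 by 2,4,5-trimethylphenyl in place of 4-(bromomethyl)phenyl on an aromatic carbon. The change swaps a 4-(bromomethyl)phenyl for a 2,4,5-trimethylphenyl on an aromatic carbon. Of the measured steps, a step that the limit leaves unreadable from compound 1 to compound 3 and a step that the two limits leave unreadable from compound 2 to compound 3 concern the same aromatic carbon, but neither yields a size, so no direction can be taken from them. With every value of the three either high or a limit, no step beyond the scatter is expected from compound 3 to compound 4 in this assay, a step that the limit leaves unreadable from compound 3 to compound 4. Compound 4 is thus estimated at 70 uM in this assay, with a range from 25 uM to 200 uM.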

Compound 4, concentration for half-maximal effect: 8.2 uM
Compound 4: middle estimate off by 8.5-fold (0.93 log units), on the high side; measured number outside the range, below it.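

Among these compounds, the first change readable for size is an at least 5.6-fold lower number from compound 3 to compound 4 (0.75 log units; beyond the scatter), which shows that in this assay the number responds to the aryl group held on this aromatic carbon next to the ring oxygen. The earlier steps shown here cannot be read for size, so they gave no sign of this, and here the response appears between two groups that each hold one six-membered aromatic ring of carbon only and neither a hydrogen-bond donor nor an acceptor. The true size of the step stays unknown, because compound 3 reaches only a limit: the limit of > 46.5 uM in this assay, at which 1 of the 4 values shown sits.

The change removes the bromomethyl group and brings in the 2,4,5-trimethylphenyl pattern in one move, so the compounds shown leave open which methyl group carries the step and whether loss of the bromine plays any part. They also leave open how an unsubstituted phenyl, or a phenyl bearing an amine or a carboxylic acid, would read on this carbon with the shared core unchanged.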